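A few compounds are considered here, and "the series" means these few. Any claim that something is new, unique, unknown or untested is made for them only; others in the source may bear on it.

Series notes. The shared core is that of compound 1 `O=C1NC(=O)C2(CSC3=C2C(=O)c2ncccc2C3=O)N1`, the parent without an aryl group; in a functional assay on HT-29 cells (Homo sapiens) for antiproliferative activity, read by MTT assay, with a stated time of 96 h (on this read-out higher numbers stand for weaker inhibition and lower numbers for stronger inhibition), compound 1 gives 190 nM; 180 nM; 190 nM (3 entries), repeat entries recorded as the several entries of compound 1 in this assay, 190 nM; 180 nM; 190 nM (3 entries). Compound 2 `O=C1C2=C(C(=O)c3ncccc31)C1(CS2)NC(=O)N(c2ccc(Cl)cc2)C1=O` carries an aryl group bearing chloro on an aromatic carbon, and in this assay compound 2 gives 2 nM. Compound 3 `CCc1ccc(N2C(=O)NC3(CSC4=C3C(=O)c3ncccc3C4=O)C2=O)cc1` carries ethyl in place of that chloro; in this assay compound 3 gives 1 nM. Compound 3 stands beside compound 2 among the two single numbers, the pair separated only by a 2.0-fold lower number from compound 2 to compound 3 (0.30 log units; within the scatter), a step within the scatter; compound 1 has no single number and its entries sit well apart from both.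

Compound 4 `Cc1ccc(N2C(=O)NC3(CSC4=C3C(=O)c3ncccc3C4=O)C2=O)cc1` differs from compound 3 by hydrogen in place of methyl on a saturated chain carbon bound to an aromatic carbon, which read one bond further out exchanges 4-ethylphenyl for 4-methylphenyl. Going by the values given here, the only measured step bearing on this change is a 2.0-fold lower number from compound 2 to compound 3 (0.30 log units; within the scatter), itself within the scatter, so no step beyond the scatter is expected in this assay; the expected step is a 2.0-fold higher number from compound 3 to compound 4 (0.30 log units; within the scatter). Compound 4 is therefore estimated at 2 nM in this assay, within a range of 0.7 nM to 6 nM.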

Compound 4, half-maximal inhibitory concentration: 1 nM
Beside the measured number, compound 4's estimate is 2.0-fold (0.30 log units) above it, within the range that was stated.
By their numbers in this assay, from the lowest: compounds 3, 4 and 2 (each within the scatter of the next).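

In this assay, this assay, the exchange of 4-ethylphenyl for 4-methylphenyl gives no change at the digits printed from compound 3 to compound 4 (within the scatter) and so shows that removing methyl from a saturated chain carbon bound to an aromatic carbon produces no step beyond the scatter. Methyl in place of chloro on an aromatic carbon gives a 2.0-fold lower number from compound 2 to compound 4 (0.30 log units; within the scatter) and adds a second step within the scatter for replacing chloro, so compound 2, compound 3 and compound 4 cannot be ordered here. The entries of the parent give a direct view of how closely readings repeat in this assay: the several entries of compound 1 in this assay, 190 nM; 180 nM; 190 nM (3 entries).

The compounds shown leave open whether the aryl group keeps these values when it carries an amine, a carboxylic acid or a longer chain such as butyl on an aromatic carbon. Also open, going by these compounds, is how a plain phenyl group, with hydrogen in place of the methyl of compound 4, would read.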